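Replacing the quinazolin-5-yl group of compound 2

The compounds below may be only part of what the source reports. "The series", "measured", "known", "first", "only" and "open" are said of these compounds alone.

Compound 1 `Cc1cc(F)cnc1N1CCN(C(=O)CCCc2cccc3cncnc23)[C@@H](C)C1` and compound 2 `Cc1cc(F)cnc1N1CCN(C(=O)CCCc2cccc3ncncc23)[C@@H](C)C1` are two closely related amides. In an ADME assay on microsomes from liver (Rattus norvegicus) for metabolic stability, read by LC-MS, with a stated time of 15 min, tested at 1 uM (on this read-out higher numbers stand for a more stable compound and lower numbers for a less stable compound), compound 1 has the entry "not determined" (no result reported), while compound 2 gives 0%. Going by the values given here, that is the only number available, so compound 2 cannot yet be ranked against a measured neighbour. Compound 3 `Cc1cc(F)cnc1N1CCN(C(=O)CCCc2cccc3nc(N)sc23)[C@@H](C)C1` differs from compound 2 in one place, on a saturated chain carbon, three bonds along the chain from a carbonyl carbon: 2-amino-1,3-benzothiazol-7-yl in place of quinazolin-5-yl on a saturated chain carbon, three bonds along the chain from a carbonyl carbon. Among the compounds with values here, no measured step shows what such an exchange does. Since compound 2 stands at 0%, the read-out has no room to fall. The expected change is small and upward, within the usual scatter, an estimated a number 5 percentage points higher from compound 2 to compound 3 (within the scatter). In this assay, the estimate for compound 3 is 5%, with an expected range of 0% to 20%.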

Compound 3, percent of the compound remaining: 3.7%
Compound 3: middle estimate off by 1.3 percentage points, on the high side; measured number inside the range.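

In this assay, going by these compounds alone, the exchange of quinazolin-5-yl for 2-amino-1,3-benzothiazol-7-yl reads as a number 3.7 percentage points higher from compound 2 to compound 3 (within the scatter), the first measured step at this place, on a saturated chain carbon, three bonds along the chain from a carbonyl carbon. The two groups differ in their rings, and the entering one carries a sulfur and a hydrogen-bond donor that the leaving one lacks, yet these differences do not separate compound 3 from compound 2 on this read-out, and both sit at the low end of its range. No measurement at hand bears on why the result came out this way.

Still open, from the compounds shown here alone, is whether any group at this place can lift the read-out clear of the scatter, for example a carboxylic acid, a primary amine or a plain phenyl ring. Going by these compounds, it is equally open whether a longer chain, or a change elsewhere on the shared core, would matter more than the group exchanged here.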